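Furan-2-yl to furan-3-yl in a cytotoxicity test

The compounds below may be only part of what the source reports. "The series", "measured", "known", "first", "only" and "open" are said of these compounds alone.

Measured in an ADME assay on MRC5 cells (Homo sapiens) for cytotoxicity, read by MTT assay, with a stated time of 72 h; on this read-out higher numbers stand for lower toxicity in this test and lower numbers for higher toxicity in this test:
Compound 1 `OC[C@H]1O[C@@H](n2cc(F)c3c(-c4ccoc4)ncnc32)[C@H](O)[C@@H]1O`: 15400 nM
Compound 2 `OC[C@H]1O[C@@H](n2cc(Cl)c3c(-c4ccco4)ncnc32)[C@H](O)[C@@H]1O`: > 50000 nM, a limit of the assay

Compound 2 stands only at a limit, not at a number. Compound 3 `OC[C@H]1O[C@@H](n2cc(Cl)c3c(-c4ccoc4)ncnc32)[C@H](O)[C@@H]1O` has the same atoms as compound 2, joined differently: furan-3-yl in place of furan-2-yl on an aromatic carbon. Among the measured compounds shown here, no measured pair shows this change alone. Compound 1 also carries furan-3-yl, and compound 1 gives 15400 nM, so a move towards lower numbers in this assay, meaning higher toxicity, is expected. The estimated value for compound 3 is 22000 nM, with an expected range from 7000 nM to 50000 nM. The expected change is an at least 2.2-fold lower number from compound 2 to compound 3 (0.35 log units; beyond the scatter).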

Compound 3, half-maximal cytotoxic concentration: > 50000 nM
Compound 3 ended at the assay's limit (the forecaster's own chance of this, stated with the estimate: 30%); at least 2.2-fold (0.35 log units) between middle value and limit.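

In this assay compound 3 gives > 50000 nM as a limit of the assay, not a number. The swap of furan-2-yl for furan-3-yl therefore cannot be read, since both chloro compounds stop at the same ceiling: the limit of > 50000 nM in this assay, at which 2 of the 3 values shown sit. What can be read is chloro in place of fluoro on an aromatic carbon, with furan-3-yl held fixed, which gives an at least 3.2-fold higher number from compound 1 to compound 3 (0.51 log units; beyond the scatter) on this read-out.

As far as these compounds go, whether the two furans differ at all in the chloro series stays open. So does the effect of an amine or a longer chain in place of the furan.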